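The source may report more compounds than this note shows. Statements on the series, on what has been measured and on what is new or still open speak of the compounds shown alone.

Measured compounds:
compound 1, `c1ccc(-c2nnc(-c3c[nH]c4ccccc34)o2)cc1`: > 1000000 nM
compound 2, `COc1ccc(-c2nnc(-c3c[nH]c4ccccc34)o2)cc1OC`: > 1000000 nM
compound 3, `COc1cc(-c2nnc(-c3cn(C)c4ccccc34)o2)ccc1OCc1ccccc1`: 1400 nM

In a functional assay on MIA PaCa-2 cells (Homo sapiens) for cytotoxicity, read by MTT assay (on this read-out lower numbers stand for stronger inhibition and higher numbers for weaker inhibition), compound 1 gives > 1000000 nM, which is a limit of the assay and not a number. Compound 2 likewise sits at a limit in this assay, > 1000000 nM. Among the compounds with values here, compound 3 is the one compound with a number, giving 1400 nM in this assay. Compound 1 therefore stands at the weak end of what has been measured: it cannot be placed above or below compound 2, and it is separated from compound 3 only by the fact that compound 3 returns a number while compound 1 does not. the limit of > 1000000 nM in this assay, at which 2 of the 3 values shown sit, marks where two of the three measured compounds sit.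

Compound 4, `Cc1nnc(-c2c[nH]c3ccccc23)o1`, is not yet measured. It differs from compound 1 by methyl in place of phenyl on an aromatic carbon. Within the data shown here, no pair of measured compounds differs in a single place, so the size of this step has no measured counterpart. Compound 1 sits at the limit in this assay, and removing the phenyl leaves a smaller compound with less of the structure that compound 3 carries. The step that the limit leaves unreadable from compound 1 to compound 4 is expected to be none beyond the scatter, with compound 4 expected to remain at the limit. Compound 4 is expected to give 2000000 nM in this assay, between 300000 nM and 10000000 nM.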

Compound 4, half-maximal inhibitory concentration: 145000 nM
Compound 4: middle estimate off by 14-fold (1.14 log units), on the high side; the whole stated range lies above it.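

In this assay, within the data shown here, methyl in place of phenyl on an aromatic carbon, next to the ring nitrogen and next to the ring oxygen, gives an at least 6.8-fold lower number from compound 1 to compound 4 (0.83 log units; beyond the scatter), the first change that can be read at a single place. As far as these compounds go, the value of compound 1, > 1000000 nM, is a limit of the assay and not a number, so the step gives only its smallest possible size, and its full size stays unknown: the limit of > 1000000 nM in this assay, at which 2 of the 4 values shown sit. The step shows that this position affects the read-out and that the phenyl, with its six-membered aromatic ring of carbon only, is not needed for a numerical value on this core, while the hydrogen-bond donor and acceptor counts of the two groups are the same.

With only phenyl and methyl at this position, the data cannot separate the loss of the ring from the drop in heavy atoms, and an ethyl, a longer chain, an amine or a carboxylic acid there would be needed to tell how the read-out follows the group. Among these compounds, whether the same change carries over to the more substituted compound 3 also stays open, as no single-place step links that compound to the others.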